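A few compounds are considered here, and "the series" means these few. Any claim that something is new, unique, unknown or untested is made for them only; others in the source may bear on it.

Of the compounds shown here, two from this series have been measured in an assay for inhibition of inositol hexakisphosphate kinase 2 (Homo sapiens), read by colorimetric assay, coupled enzyme assay and malachite green, with a stated time of 120 min, in the presence of a further agent that is not named here; a higher number here means a weaker inhibitor, a lower number a stronger inhibitor. Compound 1 `Cc1ccc(-c2onc3ccc(/C=C/C(=O)O)cc23)cc1` gives 6510 nM in this assay. Compound 2 `O=C(O)c1ccc2noc(-c3ccc(-c4cccnc4)cc3)c2c1` gives 54 nM in this assay, the lowest of the two numbers recorded, and the gap to compound 1 lies well beyond the scatter of the method. Going by the values given here, the two structures differ in more than one place, so the comparison says only that compound 2 is the far stronger inhibitor of the pair.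

Compound 3 `O=C(O)c1ccc2noc(-c3ccc(N4CCCC4=O)cc3)c2c1` has not yet been tested. It keeps the carboxylic acid and the shared core of compound 2 and changes only one group on an aromatic carbon of a six-membered aromatic ring of carbon only: 2-oxopyrrolidin-1-yl in place of pyridin-3-yl on an aromatic carbon

Among the compounds with values here, no measured pair in this set isolates such a change, so the expectation rests on the structural difference alone. A loss of potency beyond the scatter is expected, with a step of a 6.5-fold higher number from compound 2 to compound 3 (0.81 log units; beyond the scatter) in this assay. Compound 3 is accordingly estimated at 350 nM in this assay. The range expected for compound 3 runs from 70 nM to 1800 nM.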

Compound 3, half-maximal inhibitory concentration: 480 nM
Estimate against measurement, compound 3: 1.4-fold (0.14 log units) below, and the stated range covers the measured number.
By their numbers in this assay, from the lowest: compound 2; then compound 3; then compound 1.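

Going by these compounds alone, compound 2 and compound 3 are the first pair here that differ in one place only, so the group on this aromatic carbon, para to a large group, can now be read on its own in this assay. Putting 2-oxopyrrolidin-1-yl in place of pyridin-3-yl gives an 8.9-fold higher number from compound 2 to compound 3 (0.95 log units; beyond the scatter), although both groups have 6 heavy atoms, 0 hydrogen-bond donors, 1 hydrogen-bond acceptor and no net charge, which shows that this position responds to a change that leaves those counts untouched and alters the ring itself, from a six-membered aromatic ring to a five-membered non-aromatic ring bearing a carbonyl. Nothing measured here accounts for the size of this step.

The compounds shown leave open whether the ring nitrogen of pyridin-3-yl matters at all, since neither a plain phenyl nor pyridin-4-yl stands at this position for comparison. They also leave open how an open-chain amide such as acetamido, or a saturated six-membered ring such as morpholin-4-yl, would compare with 2-oxopyrrolidin-1-yl on the same carbon.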